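Methyl on an Oxygen: From Compound 1 to Compound 4

The source may report more compounds than this note shows. Statements on the series, on what has been measured and on what is new or still open speak of the compounds shown alone.

Compound 1 `O=C(Nc1cccc(-n2cc(-c3ccncc3)c(-c3ccc(Cl)c(O)c3)n2)c1)Nc1ccc(Cl)c(Cl)c1` gives 1230 nM in a functional assay on HCT-15 cells (Homo sapiens) for inhibition, read by sulforhodamine B assay, with a stated time of 48 h; a lower number here means a stronger inhibitor of growth, a higher number a weaker inhibitor of growth.
Compound 2 `COc1cc(-c2nn(-c3cccc(NC(=O)c4cccc(C(F)(F)F)c4)c3)cc2-c2ccncc2)ccc1Cl` gives 1550 nM in this assay.
Compound 3 `COc1cc(-c2nn(-c3cccc(NC(=O)Nc4ccc(Cl)c(C(F)(F)F)c4)c3)cc2-c2ccncc2)ccc1Cl` gives 1230 nM in this assay.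

Compound 1 stands level with compound 3 at the digits given, and together they are the lowest of the three numbers; compound 2 lies within the scatter of both. For the measured compounds named here, the one measured step, a 1.3-fold lower number from compound 2 to compound 3 (0.10 log units; within the scatter), alters the group on the carbonyl carbon and stays within the scatter, so none of the three compounds can be called stronger or weaker than another.

Compound 4 `COc1cc(-c2nn(-c3cccc(NC(=O)Nc4ccc(Cl)c(Cl)c4)c3)cc2-c2ccncc2)ccc1Cl` differs from compound 1 by methyl in place of hydrogen on an oxygen on an aromatic ring. No measured step touches this oxygen, so nothing shown bears directly on the change. Going by the values given here, the only indirect guide is that compounds 2 and 3, which carry the methoxy, sit within the scatter of compound 1, which carries the hydroxy. Compound 4 is therefore expected to show a step of a 1.0-fold lower number from compound 1 to compound 4 (0.01 log units; within the scatter), nothing beyond the scatter. Compound 4 is estimated at 1200 nM, with a range from 600 nM to 2500 nM.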

Compound 4, concentration for 50% growth inhibition: 1230 nM
Compound 4: the middle estimate sits 1.0-fold (0.01 log units) below what was measured; the measured number falls inside the stated range.
By their numbers in this assay, from the lowest: compounds 1, 3, 4 and 2 (each within the scatter of the next).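

For the compounds shown here, this is the first direct reading at this oxygen: in this assay, replacing hydroxy with methoxy gives no change at the digits printed from compound 1 to compound 4 (within the scatter), so adding the methyl produces no step beyond the scatter when the 3,4-dichlorophenyl group is present. With the methoxy held in place, changes at the other end also stay within the scatter: chloro in place of trifluoromethyl gives no change at the digits printed from compound 3 to compound 4 (within the scatter), and (3,4-dichlorophenyl)amino in place of 3-(trifluoromethyl)phenyl on the carbonyl carbon gives a 1.3-fold lower number from compound 2 to compound 4 (0.10 log units; within the scatter). Nothing available offers an explanation for how close these numbers are.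

Going by these compounds, it remains open whether a longer chain on this oxygen, such as ethyl or propyl, or an amine in place of the hydroxy, would also stay within the scatter. Going by these compounds alone, every step so far lies within it, so it is also unknown which change, if any, would move the number beyond it.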